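Bromo for Trifluoromethoxy: Compound 1 to Compound 4

The source may hold more compounds than are shown below. What is called first, only, known or untested is meant among the compounds shown, and "the series" means these compounds.

Compound 1 `O=C(/C(=C\c1ccc(OC(F)(F)F)cc1)S(=O)(=O)c1ccc(Br)cc1)c1ccc(Br)cc1` gives the highest number of the three compounds measured in a functional assay on DU-145 cells (Homo sapiens) for inhibition, read by trypan blue exclusion, with a stated time of 96 h (on this read-out lower numbers stand for stronger inhibition of growth and higher numbers for weaker inhibition of growth), where compound 1 gives 25000 nM. Within the data shown here, its nearest neighbour is compound 3 `O=C(/C(=C\c1ccc(OC(F)(F)F)cc1)Sc1ccc(Br)cc1)c1ccc(Br)cc1`, which in this assay gives 10000 nM; the only single-point step measured, a 2.5-fold lower number from compound 1 to compound 3 (0.40 log units; beyond the scatter), concerns (4-bromophenyl)sulfanyl in place of (4-bromophenyl)sulfonyl and says nothing about the aryl substituent. Compound 2 `O=C(/C(=C/c1ccc(Cl)cc1)Cc1ccc(Cl)c(Cl)c1)c1ccc(Cl)cc1Cl` differs from compound 1 in several places at once; in this assay compound 2 gives 1000 nM. Compound 4 `O=C(/C(=C\c1ccc(Br)cc1)S(=O)(=O)c1ccc(Br)cc1)c1ccc(Br)cc1` differs from compound 1 by bromo in place of trifluoromethoxy on an aromatic carbon. Among the measured compounds shown here, no measured step touches this change, and the data hold no other pair in which a trifluoromethoxy gives way to a bromo. The expectation for compound 4 therefore rests on its close kinship with compound 1: compound 4 is expected to sit near compound 1, with a step of a 1.3-fold lower number from compound 1 to compound 4 (0.10 log units; within the scatter) that need not exceed the usual scatter. In this assay compound 4 is estimated at 20000 nM, with a range from 7000 nM to 50000 nM.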

Compound 4, concentration for 50% growth inhibition: 10000 nM
Compound 4: middle estimate off by 2.0-fold (0.30 log units), on the high side; measured number inside the range.
By their numbers in this assay, from the lowest: compound 2; then compounds 3 and 4 (each within the scatter of the next); then compound 1.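

In this assay the step of a 2.5-fold lower number from compound 1 to compound 4 (0.40 log units; beyond the scatter) is the only one among these compounds measured at this place, on an aromatic carbon of a six-membered aromatic ring of carbon only, para to a large group. It shows that this position is not silent: with the (4-bromophenyl)sulfonyl group kept, bromo in place of trifluoromethoxy gives a modest change that lies beyond the scatter. No measurement at hand bears on why the number moves with this exchange.

From the compounds shown here alone, whether an amine, a carboxylic acid or a longer chain on this aromatic carbon would move the number further remains open. Also open, going by these compounds, is whether the same exchange would give a similar step on compound 3, which carries the (4-bromophenyl)sulfanyl group, and a single exchange sets no trend for this position.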